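This account rests on a few compounds, and the source may have more. Where it says the series, first, only, none or still open, it means among the compounds named here.

Among the compounds with values here, compound 2, `CCc1ccc(S(=O)(=O)N2CCC(N3CCC(C)CC3)CC2)cc1`, is one of three compounds measured in a functional assay on DLD-1 cells (Homo sapiens) for antiproliferative activity, read by CellTiter-Glo, with a stated time of 72 h; on this read-out higher numbers stand for weaker inhibition and lower numbers for stronger inhibition. Compound 1, `CC1CCN(C2CCN(S(=O)(=O)c3cccc(-c4ccccc4C(F)(F)F)c3)CC2)CC1`, gives 10 nM in this assay. Compound 3, `Cc1c(C)c(S(=O)(=O)N2CCC(N3CCC(C)CC3)CC2)c(C)c2c1OC(C)(C)C2`, gives 1.2 nM in this assay. Compound 2 stands apart from these two in this assay: its result is a limit, not a number, at > 5000 nM, so only its position beyond the range of the assay is known, and this is the limit of > 5000 nM in this assay, at which 1 of the 3 values shown sits. Nothing can be said about how far beyond that limit compound 2 actually lies.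

Compound 4, `CC1CCN(C2CCN(S(=O)(=O)c3ccc(C#N)cc3)CC2)CC1`, has not yet been measured in this assay. It differs from compound 2 in one place: cyano in place of ethyl on an aromatic carbon. Compound 4 keeps the same sulfonamide and the same piperidine parts as compound 2 and is changed only at the para position of the phenyl ring.

Within the data shown here, since no pair of measured compounds differing in one place is available, the size of the step from compound 2 to compound 4 cannot be drawn from the data. Compound 1 and compound 3 carry substantially larger groups on the aromatic ring than compound 2, and only these two give numbers in this assay. Compound 4 is therefore expected to stay near compound 2, with an estimated step of an at least 1.2-fold lower number from compound 2 to compound 4 (0.09 log units; that floor lies within the scatter) in this assay, and a likely chance of again returning only a limit. Compound 4 is estimated at 4000 nM in this assay, with a range from 600 nM to 20000 nM.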

Compound 4, half-maximal inhibitory concentration: 2800 nM
Compound 4: the middle estimate sits 1.4-fold (0.15 log units) above what was measured, within the range that was stated.
By their numbers in this assay, from the lowest: compound 3; then compound 1; then compound 4. At a limit, above all of these: compound 2.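

Compound 2 gives > 5000 nM in this assay, and this is a limit, not a number. The change from 4-ethylphenyl to 4-cyanophenyl swaps one group of 2 heavy atoms for another and adds 1 hydrogen-bond acceptor, and at this position, para to a large group, it yields a result that reads as a number rather than a limit, with an at least 1.7-fold lower number from compound 2 to compound 4 (0.25 log units; that floor lies within the scatter) in this assay. The true size of this step cannot be stated, because only one end of it is a number: the limit of > 5000 nM in this assay, at which 1 of the 4 values shown sits.

The compounds shown leave open whether cyano is special at this position, or whether another group there, such as an amine, a carboxylic acid or a longer chain, would also give a number in this assay. They also leave open what cyano would do at another place on the aromatic ring or on the more heavily substituted aromatic parts of compound 1 and compound 3, since neither of those compounds differs from compound 4 in only one place.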